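Dropping a methoxy group: what to expect for compound 4

A few compounds are considered here, and "the series" means these few. Any claim that something is new, unique, unknown or untested is made for them only; others in the source may bear on it.

Measured so far in a functional assay on HL-60 cells (Homo sapiens) for cytotoxicity; a higher number here means that more compound is tolerated, a lower number that less compound is tolerated:
Compound 1, `COc1cc(/C=C2\CC/C(=C\c3ccc([N+](=O)[O-])cc3)C2=O)cc(OC)c1OC`: > 400000 nM, a limit of the assay rather than a number.
Compound 2, `COc1cc(/C=C2\CCC/C(=C\c3ccc([N+](=O)[O-])cc3)C2=O)ccc1O`: 3400 nM.
Compound 3, `COc1ccc(/C=C2\CCC/C(=C\c3ccc([N+](=O)[O-])cc3)C2=O)cc1OC`: 4300 nM.

Compound 1 reports only a limit, so it gives no number to compare. Among the two numbers, compound 2 sits at the lower one; its nearest neighbour is compound 3, and a 1.3-fold higher number from compound 2 to compound 3 (0.10 log units; within the scatter). Those two values therefore cannot be told apart.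

Compound 4, `O=C1/C(=C/c2ccc(O)cc2)CCC/C1=C\c1ccc([N+](=O)[O-])cc1`, is not yet measured. It differs from compound 2 by hydrogen in place of methoxy on an aromatic carbon; read one bond further out, a 4-hydroxy-3-methoxyphenyl becomes a 4-hydroxyphenyl. Among the compounds with values here, no measured step removes this methoxy. Within the data shown here, the only measured change on the same ring, the methylation of the hydroxy group from compound 2 to compound 3, stayed within the scatter. On that basis, and with nothing else to go on, no step beyond the scatter is expected in this assay, in either direction, though the range must stay wide. Compound 4 is estimated at 5000 nM, with an expected range from 1500 nM to 16000 nM. That estimate means an expected step of a 1.5-fold higher number from compound 2 to compound 4 (0.17 log units; within the scatter).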

Compound 4, half-maximal cytotoxic concentration: 4400 nM
For compound 4 the middle estimate is 1.1-fold (0.06 log units) above the measured one, within the range that was stated.
By their numbers in this assay, from the lowest: compounds 2, 3 and 4 (each within the scatter of the next). At a limit, above all of these: compound 1.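

Hydrogen can stand in place of the methoxy group on this ring with no step that can be told from the scatter in this assay: a 1.3-fold higher number from compound 2 to compound 4 (0.11 log units; within the scatter). Within the data shown here, until now the only measured change on this ring was at the hydroxy group, where adding a methyl gave a 1.3-fold higher number from compound 2 to compound 3 (0.10 log units; within the scatter), so the carbon ortho to the hydroxy group had not been tested on its own. The methoxy group, with its two heavy atoms and its hydrogen-bond acceptor, can therefore go without a readable change in this assay, although nothing shown accounts for that.

The compounds shown leave open whether any other group at this position, such as an amine, a carboxylic acid or a longer chain like ethoxy, would also stay within the scatter of compound 2, or would move the number clearly in either direction. Going by these compounds, compound 1 gives > 400000 nM, which is a limit of the assay and not a number, and it differs from compound 2 in more than one place, so what sets it apart remains open.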